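The source may report more compounds than this note shows. Statements on the series, on what has been measured and on what is new or still open speak of the compounds shown alone.

Measured compounds:
- compound 1, `CN(CCCN1CCCCC1)c1ccc(C(=O)N2CCc3ccc(OS(N)(=O)=O)cc3C2)cc1`: 1.93
- compound 2, `NS(=O)(=O)Oc1ccc2c(c1)CN(C(=O)c1ccc(N3CCCCC3)cc1)CC2`: 1.93
- compound 3, `CCN(Cc1cccnc1)c1ccc(C(=O)N2CCc3ccc(OS(N)(=O)=O)cc3C2)cc1`: 1.93

In a physicochemical assay for lipophilicity (a lower number here means a more polar compound, a higher number a more lipophilic compound), compound 3 sits level with compounds 1 and 2: the steps of no change at the digits printed from compound 1 to compound 3 (within the scatter) and no change at the digits printed from compound 2 to compound 3 (within the scatter) are both flat, as is no change at the digits printed from compound 1 to compound 2 (within the scatter). Three different amino substituents on the shared core thus give the same reading within the scatter.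

Compound 4, `CCN(Cc1ccc(F)cc1)c1ccc(C(=O)N2CCc3ccc(OS(N)(=O)=O)cc3C2)cc1`, is the next compound, differing from compound 3 in one place: 4-fluorophenyl in place of pyridin-3-yl on a saturated chain carbon bound to a nitrogen on an aromatic ring. The hydrogen-bond acceptor counted for pyridin-3-yl leaves and nothing of that kind enters with 4-fluorophenyl.

Among the measured compounds shown here, none of the measured steps makes this swap of one aromatic ring for another on the saturated chain carbon; they only show that the earlier changes at the amino group left this assay unmoved. For the measured compounds named here, with no step to anchor it, the estimate rests on the counted loss of an acceptor, and a rise beyond the scatter is expected for compound 4, of about a number 0.97 log units higher from compound 3 to compound 4 (beyond the scatter). Compound 4 is therefore estimated at 2.9, within a range from 2.3 to 3.5.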

Compound 4, partition coefficient: 1.93
Beside the measured number, compound 4's estimate is 0.97 log units above it; measured number outside the range, below it.
By their numbers in this assay, from the lowest: compounds 1, 2, 3 and 4 (each within the scatter of the next).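

In this assay, the step from pyridin-3-yl to 4-fluorophenyl on a saturated chain carbon bound to a nitrogen on an aromatic ring reads no change at the digits printed from compound 3 to compound 4 (within the scatter) and so shows that the departure of the counted hydrogen-bond acceptor leaves the reading flat. The earlier compounds shown here had exchanged only whole amino groups, whereas this change replaces one aromatic ring with another at this position, and ethyl(4-fluorobenzyl)amino also matches the two other amino groups, with no change at the digits printed from compound 2 to compound 4 (within the scatter) and with no change at the digits printed from compound 1 to compound 4 (within the scatter) as the steps. Nothing available accounts for this flat reading.

On these data alone, whether a carboxylic acid in place of the 4-fluorophenyl would move this assay beyond the scatter remains open. The same question stands for a longer chain in place of the ethyl.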